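Thioether series: cytotoxicity notes on compounds 1 to 3

The source may hold more compounds than are shown below. What is called first, only, known or untested is meant among the compounds shown, and "the series" means these compounds.

Measured so far:
compound 1 `CCOC(=O)CSc1nnc(C)n1N1C(=O)c2ccccc2C1=O`: > 200000 nM
compound 2 `CCc1nnc(SCC(=O)c2ccc(Cl)cc2)n1N1C(=O)c2ccccc2C1=O`: > 200000 nM

In a functional assay on MKN-45 cells (Homo sapiens) for cytotoxicity, read by MTT assay, with a stated time of 48 h (on this read-out lower numbers stand for stronger inhibition and higher numbers for weaker inhibition), compound 1 gives only a limit, > 200000 nM. In this assay compound 2 likewise gives only a limit, > 200000 nM. Both values sit at the limit of > 200000 nM in this assay, at which 2 of the 2 values shown sit, so compound 2 stands at the limit with nothing to set it apart. Compound 3 `CCOC(=O)CSc1nnc(CC)n1N1C(=O)c2ccccc2C1=O` differs from compound 2 by ethoxy in place of 4-chlorophenyl on a carbonyl carbon. Within the data shown here, no measured step for a single change exists in this set. Compound 3 is expected to remain at the limit, the step that the limit leaves unreadable from compound 2 to compound 3 being none beyond the scatter. Compound 3 is estimated at 250000 nM, between 100000 nM and 800000 nM, most likely reported again only as a limit.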

Compound 3, half-maximal inhibitory concentration: > 200000 nM
Compound 3: a limit, no number; the forecaster's own chance of this, stated with the estimate: 85%; the middle value lies beyond the limit too.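

No step can be read from compound 3 to compound 1 or compound 2, as each value is a limit and not a number: the limit of > 200000 nM in this assay, at which 3 of the 3 values shown sit. In this assay the compounds shown leave open whether any change on the shared core gives a value that is a number.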